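The source may report more compounds than this note shows. Statements on the series, on what has been measured and on what is new or still open speak of the compounds shown alone.

In an ADME assay on MDBK cells (Bos taurus) for cytotoxicity (a lower number here means that less compound is tolerated, a higher number that more compound is tolerated), three compounds with a shared core have been measured so far. Compound 1 `c1ccc(Cn2ccc3nc(-c4ccccc4)nc-3c2)cc1` gives > 100000 nM, a limit of the assay and not a number. Compound 2 `Fc1ccc(Cn2ccc3nc(-c4ccccc4)nc-3c2)cc1` gives > 100000 nM, which is also a limit. Compound 3 `N#Cc1ccc(Cn2ccc3nc(-c4ccccc4)nc-3c2)cc1` gives > 100000 nM, so it too stands at a limit, with no number of its own. Among the measured compounds shown here, the series so far shows (the limit of > 100000 nM in this assay, at which 3 of the 3 values shown sit).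

Compound 4 `CC(C)(C)c1ccc(Cn2ccc3nc(-c4ccccc4)nc-3c2)cc1` carries tert-butyl in place of cyano on an aromatic carbon, para to a large group: tert-butyl in place of cyano on an aromatic carbon.

For the measured compounds named here, three measured steps bear on this place: a step that the two limits leave unreadable from compound 1 to compound 2, a step that the two limits leave unreadable from compound 1 to compound 3 and a step that the two limits leave unreadable from compound 2 to compound 3. None of them has a readable size, so they offer no measured effect to carry over. In this assay, on these data alone, the expectation is therefore no clear step, with some allowance for a lower reading, since tert-butyl is untested here.

For compound 4 the estimate is 80000 nM, with an expected range from 30000 nM to 100000 nM. The expected step is an at least 1.2-fold lower number from compound 3 to compound 4 (0.09 log units; that floor lies within the scatter).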

Compound 4, half-maximal cytotoxic concentration: 22000 nM
The estimate for compound 4 lay 3.6-fold (0.56 log units) above the measured number, outside the stated range (below it).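

In this assay, among the compounds shown here, this position on an aromatic carbon, para to a large group, now shows a change of readable size for the first time. Tert-butyl in place of cyano gives an at least 4.5-fold lower number from compound 3 to compound 4 (0.65 log units; beyond the scatter), tert-butyl in place of fluoro gives an at least 4.5-fold lower number from compound 2 to compound 4 (0.65 log units; beyond the scatter), and tert-butyl in place of hydrogen gives an at least 4.5-fold lower number from compound 1 to compound 4 (0.65 log units; beyond the scatter). These sizes are floors only, and the steps among the three earlier compounds cannot be read, for one shared reason: the limit of > 100000 nM in this assay, at which 3 of the 4 values shown sit.

The compounds shown leave open whether an isopropyl group, a methoxy group, an amine or a carboxylic acid at this place would also give a reading under the limit. For the compounds shown here, with tert-butyl as the only group to give a number, they also leave open how far the reading depends on this one group.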